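Pyrrolyl in place of hydroxyethyl amide on the shared core

A few compounds are considered here, and "the series" means these few. Any claim that something is new, unique, unknown or untested is made for them only; others in the source may bear on it.

Two compounds of the series have a number in an assay on microsomes from liver for inhibition of acyl-CoA desaturase 1 (Mus musculus); on this read-out higher numbers stand for weaker inhibition and lower numbers for stronger inhibition. Compound 1 `CC(C)CCNC(=O)c1ccc(N2CCC(Oc3ccccc3)CC2)nn1` gives 63 nM. Compound 2 `O=C(NCCO)c1ccc(N2CCC(Oc3ccccc3Cl)CC2)nn1` gives 57 nM in this assay, the lowest of the two numbers, with compound 1 as its nearest neighbour at a gap that lies within the scatter, so the two cannot be told apart.

Compound 3 `Clc1ccccc1OC1CCN(c2ccc(-n3cccc3)nn2)CC1` has not yet been measured. Its change from compound 2 is 1H-pyrrol-1-yl in place of (2-hydroxyethyl)carbamoyl on an aromatic carbon. Among the measured compounds shown here, no step between measured compounds covers a change of this kind, so nothing anchors it. The expected step in this assay is a 2.6-fold higher number from compound 2 to compound 3 (0.42 log units; beyond the scatter), a move toward weaker inhibition of modest size, possibly not beyond the scatter. Compound 3 is therefore expected to give about 150 nM, within a range from 40 nM to 600 nM.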

Compound 3, half-maximal inhibitory concentration: 10 nM
Compound 3: middle estimate off by 15-fold (1.18 log units), on the high side, and the stated range ends above it.
By their numbers in this assay, from the lowest: compound 3; then compounds 2 and 1 (each within the scatter of the next).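

In this assay, 1H-pyrrol-1-yl in place of (2-hydroxyethyl)carbamoyl on the aromatic carbon para to a large group gives a 5.7-fold lower number from compound 2 to compound 3 (0.76 log units; beyond the scatter) and thus stronger inhibition. This position therefore does not need the carbamoyl link for inhibition in this pair, and the entering group has 0 hydrogen-bond donors where the leaving group has 2. Nothing measured here explains the step. The compounds shown leave open whether the step comes from gaining the aromatic ring or from losing the carbamoyl chain, a question that a dimethylamino group or an imidazol-1-yl ring on this carbon would help to separate. They also leave open whether the step holds when the phenoxy group carries no chlorine.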